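This account rests on a few compounds, and the source may have more. Where it says the series, first, only, none or still open, it means among the compounds named here.

Measured so far:
compound 1 `C=CCn1c2ccc([N+](=O)[O-])cc2c(=O)n1Cc1ccccc1`: 192000 nM
compound 2 `CCOCCCn1c2ccc([N+](=O)[O-])cc2c(=O)n1Cc1ccccc1`: 170000 nM

In an ADME assay on L929 cells (Mus musculus) for cytotoxicity, read by resazurin assay, with a stated time of 48 h (on this read-out lower numbers stand for higher toxicity in this test and higher numbers for lower toxicity in this test), compound 2 gives 170000 nM and stands level with compound 1, within the scatter. Compound 3 `Cc1ccc(S(=O)(=O)n2c3ccc([N+](=O)[O-])cc3c(=O)n2Cc2ccccc2)cc1` has (4-methylphenyl)sulfonyl in place of 3-ethoxypropyl on an aromatic nitrogen. Going by the values given here, only one measured step bears on this, a 1.1-fold lower number from compound 1 to compound 2 (0.05 log units; within the scatter), and it was within the scatter. It swapped one chain for another and brought in no sulfonyl group or added ring, so it is a weak guide. No change beyond the scatter is therefore expected, though the uncertainty is wide. The expected step is a 1.3-fold lower number from compound 2 to compound 3 (0.12 log units; within the scatter). For compound 3 the estimate is 130000 nM, with a range from 50000 nM to 300000 nM.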

Compound 3, concentration lethal to 50% of the cells: > 256000 nM
Compound 3 gave a limit, no number; the forecaster's own chance of this, stated with the estimate: 15%; at least 1.9-fold (0.29 log units) between middle value and limit.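

In this assay compound 3 gives a limit of the assay, not a number: the limit of > 256000 nM in this assay, at which 1 of the 3 values shown sits. The steps it allows are only floors: an at least 1.5-fold higher number from compound 2 to compound 3 (0.17 log units; that floor lies within the scatter), and an at least 1.3-fold higher number from compound 1 to compound 3 (0.12 log units; that floor lies within the scatter). So this aromatic nitrogen can carry a (4-methylphenyl)sulfonyl group, with its six-membered aromatic ring, and show no sign of higher toxicity in this test than the two chains. This is new. The earlier step only swapped one chain for another.

On these data alone, how far compound 3 truly lies from either chain stays open. So does whether a benzoyl group or a chain ending in an amine at this nitrogen would read the same.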